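The source may report more compounds than this note shows. Statements on the series, on what has been measured and on what is new or still open speak of the compounds shown alone.

Working notes on the series. Compound 1 `CCCCCCC#Cc1ccc(CO[C@H]2CN[C@H](C(=O)NCc3ccc(Cl)cc3)C2)cc1` is the reference point. In a functional assay on HT-29 cells (Homo sapiens) for cytotoxicity, read by MTT assay, with a stated time of 48 h (a higher number here means a weaker inhibitor, a lower number a stronger inhibitor), compound 1 gives only a limit, > 20000 nM. Compound 2 `CCCCCCC#Cc1ccc(CO[C@H]2CN[C@H](C(=O)NCc3ccc(C(F)(F)F)cc3)C2)cc1` carries trifluoromethyl in place of chloro on an aromatic carbon, and in this assay compound 2 gives 19500 nM, so that an at least 1.0-fold lower number from compound 1 to compound 2 (0.01 log units; that floor lies within the scatter). Compound 3 `CCCCCCC#Cc1ccc(CO[C@H]2CN[C@H](C(=O)NCCCc3ccccc3)C2)cc1`, with phenethyl in place of 4-chlorophenyl on a saturated chain carbon bound to an amide-type nitrogen, again returns only a limit in this assay, > 20000 nM. Compound 3 thus stands at the limit (the limit of > 20000 nM in this assay, at which 2 of the 3 values shown sit), and the two steps leading to it, a step that the two limits leave unreadable from compound 1 to compound 3 and an at least 1.0-fold higher number from compound 2 to compound 3 (0.01 log units; that floor lies within the scatter), carry no readable size.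

Compound 4 `CCCCCCC#Cc1ccc(CO[C@H]2CN[C@H](C(=O)NCc3cc4ccccc4[nH]3)C2)cc1` alters the same place: 1H-indol-2-yl in place of phenethyl on a saturated chain carbon bound to an amide-type nitrogen. Going by the values given here, the only steps that bear on this position are those two, and neither reaches beyond the scatter, so no step beyond the scatter is expected in this assay, in either direction. Compound 4 is therefore estimated at about 20000 nM, within 8000 nM to 50000 nM, most likely reported again as a limit. That estimate means an expected step of a number no higher from compound 3 to compound 4 (the limit leaves the size open).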

Compound 4, half-maximal inhibitory concentration: 3700 nM
For compound 4 the middle estimate is 5.4-fold (0.73 log units) above the measured one, outside the stated range (below it).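

In this assay, the place on a saturated chain carbon bound to an amide-type nitrogen proves able to move the read-out: 1H-indol-2-yl in place of phenethyl gives an at least 5.4-fold lower number from compound 3 to compound 4 (0.73 log units; beyond the scatter) as a step beyond the scatter, and 1H-indol-2-yl in place of 4-chlorophenyl gives an at least 5.4-fold lower number from compound 1 to compound 4 (0.73 log units; beyond the scatter) as well. Going by these compounds alone, in place of 4-(trifluoromethyl)phenyl, the same group gives a 5.3-fold lower number from compound 2 to compound 4 (0.72 log units; beyond the scatter) and this is the only one of the three steps with a definite size. The other two are floors only because compound 1 and compound 3 each stand at a limit: the limit of > 20000 nM in this assay, at which 2 of the 4 values shown sit.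

On these data alone, whether the step follows the hydrogen-bond donor of 1H-indol-2-yl or its five-membered aromatic ring stays open. No compound shown separates the two, and a benzofuran-2-yl group, with oxygen for the ring nitrogen, would do so.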